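Cytotoxicity notes on the biaryl amide series, compound 3

The compounds below may be only part of what the source reports. "The series", "measured", "known", "first", "only" and "open" are said of these compounds alone.

compound 1 `CCOC(=O)CCCCCOc1cccc(CN(C(=O)c2ccc(-c3cccc(OCC)c3)cc2)C(C)C)c1`: > 22300 nM
compound 2 `CCOC(=O)CCCCCOc1cccc(CN(C(=O)c2ccc(-c3cc(OC)ccc3F)cc2)C(C)C)c1`: > 26000 nM

In an ADME assay on Raji cells (Homo sapiens) for cytotoxicity, read by CellTiter-Glo and resazurin assay, with a stated time of 72 h (a higher number here means that more compound is needed for the effect, a lower number that less compound is needed), compound 1 gives > 22300 nM, a limit of the assay (the limit of > 22300 nM in this assay, at which 1 of the 2 values shown sits). Compound 2 gives > 26000 nM, likewise a limit (the limit of > 26000 nM in this assay, at which 1 of the 2 values shown sits). Compound 2 therefore stands at a limit, and the step that the two limits leave unreadable from compound 1 to compound 2 cannot be read. Compound 3 `CCOC(=O)CCCCCOc1cccc(CN(C(=O)c2ccc(-c3cccc(CC(=O)O)c3)cc2)C(C)C)c1` carries the change (3-(carboxymethyl)phenyl in place of 2-fluoro-5-methoxyphenyl on an aromatic carbon). For the measured compounds named here, no measured step bears readably on this change, so no shift beyond the scatter is expected; the step that the limit leaves unreadable from compound 2 to compound 3 is an estimate only. Compound 3 is expected to give 30000 nM (12000 nM to 80000 nM), most likely reported again as a limit.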

Compound 3, half-maximal effective concentration: > 26000 nM
Compound 3: a limit, no number (the forecaster's own chance of this, stated with the estimate: 80%); the middle value lies beyond the limit too.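

For the compounds shown here, compound 3 gives > 26000 nM, a limit, and compound 1 and compound 2 also stand at limits, so no step among the three can be read. The compounds shown leave open at what concentration any of them acts in this assay, and whether the 3-(carboxymethyl)phenyl group changes it.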